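The compounds below may be only part of what the source reports. "The series", "measured", "known", "first", "only" and "open" are said of these compounds alone.

Of the compounds shown here, three sharing one core have so far been measured in a functional assay (Cavia porcellus) with sulfonylurea receptors; K-ATP channels (Homo sapiens) as the target; on this read-out lower numbers stand for stronger inhibition and higher numbers for weaker inhibition. Compound 1 `CC(O)(C(=O)Nc1ccc(S(=O)(=O)c2ccccc2)c(F)c1)C(F)(F)F` gives 1800 nM in this assay. Compound 2 `CC(O)(C(=O)Nc1ccc(S(=O)(=O)c2ccccc2)c(C#N)c1)C(F)(F)F` gives 3800 nM in this assay, and the step of a 2.1-fold higher number from compound 1 to compound 2 (0.32 log units; beyond the scatter) is a modest loss. Compound 3 `CC(O)(C(=O)Nc1ccc(S(=O)(=O)c2ccccc2)c(C(F)(F)F)c1)C(F)(F)F` gives only a limit of the assay, > 30000 nM. That limit is where compound 3 stands, as the limit of > 30000 nM in this assay, at which 1 of the 3 values shown sits, records, and both steps into it, an at least 16-fold higher number from compound 1 to compound 3 (1.22 log units; beyond the scatter) and an at least 7.8-fold higher number from compound 2 to compound 3 (0.89 log units; beyond the scatter), are large losses.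

Compound 4 `CC(O)(C(=O)Nc1ccc(S(=O)(=O)c2ccccc2)c([N+](=O)[O-])c1)C(F)(F)F` has not yet been measured. It differs from compound 3 by nitro in place of trifluoromethyl on an aromatic carbon. The measured steps that bear on this change run the other way: putting trifluoromethyl in place of fluoro or cyano cost a great deal, so removing trifluoromethyl again is expected to recover much of that loss, bringing the number back down into the region of compound 1 and compound 2 rather than leaving it at the limit. Compound 4 is therefore expected to give about 5000 nM in this assay, with a range from 1500 nM to 30000 nM. Going by these compounds, the expected step of an at least 6.0-fold lower number from compound 3 to compound 4 (0.77 log units; beyond the scatter) would be a clear gain, though its exact size remains open.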

Compound 4, half-maximal inhibitory concentration: > 30000 nM
Compound 4 was reported as a limit (the forecaster's own chance of this, stated with the estimate: 30%); middle value at least 6.0-fold (0.77 log units) away from the limit.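

Compound 4, like compound 3, is recorded in this assay only as a limit and not as a number: the limit of > 30000 nM in this assay, at which 2 of the 4 values shown sit.

Nitro in place of fluoro brings an at least 16-fold higher number from compound 1 to compound 4 (1.22 log units; beyond the scatter), and nitro in place of cyano brings an at least 7.8-fold higher number from compound 2 to compound 4 (0.89 log units; beyond the scatter), so at this carbon, ortho to a phenylsulfonyl group, the loss seen with trifluoromethyl is not unique to that group. Going by these compounds, the step between compound 3 and compound 4 cannot be read, and how these two compounds rank against each other stays unknown.

The compounds shown leave open what separates the two groups that keep a measured value, fluoro and cyano, from the two that reach the limit, trifluoromethyl and nitro, and four groups are too few to settle this. On these data alone, it also remains open whether a hydrogen, a chlorine atom, a methyl group or an amine at this carbon would give a measured value, and whether any of them would give a lower number than compound 1.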